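The compounds below may be only part of what the source reports. "The series", "measured", "known", "first", "only" and "open" are said of these compounds alone.

Among the measured compounds shown here, in a functional assay on HepG2 cells (Homo sapiens) for inhibition, read by MTT assay, with a stated time of 72 h (on this read-out higher numbers stand for weaker inhibition and lower numbers for stronger inhibition), compound 1 `COc1ccc(/C=C/C(=O)c2c(O)cc(O)cc2OC)cc1` gives 18100 nM, the only true number so far. Compound 2 `COc1cc(O)cc(O)c1C(=O)/C=C/c1ccc(C)cc1` gives > 50000 nM, which is a limit of the assay. For the measured compounds named here, the one measured step, an at least 2.7-fold higher number from compound 1 to compound 2 (0.44 log units; beyond the scatter), is methyl in place of methoxy on an aromatic carbon. Compound 3 `COc1ccc(/C=C/C(=O)c2c(O)cc(O)cc2OC)cc1OC` differs from compound 1 by methoxy in place of hydrogen on an aromatic carbon, ortho to a methoxy group. The step of an at least 2.7-fold higher number from compound 1 to compound 2 (0.44 log units; beyond the scatter) replaces a methoxy and adds none, so it gives only weak guidance, and no change beyond the scatter is expected in this assay. The expected step is a 1.1-fold lower number from compound 1 to compound 3 (0.03 log units; within the scatter). For compound 3 the estimated value is 17000 nM, with an expected range of 7000 nM to 45000 nM.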

Compound 3, half-maximal inhibitory concentration: 18500 nM
Beside the measured number, compound 3's estimate is 1.1-fold (0.04 log units) below it; measured number inside the range.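

On an aromatic carbon ortho to a methoxy group and meta to a large group, methoxy in place of hydrogen is tolerated in this assay: the step is a 1.0-fold higher number from compound 1 to compound 3 (0.01 log units; within the scatter). This position therefore accepts the added methoxy with no change beyond the scatter. No measurement at hand explains this result.

As far as these compounds go, whether an amine or a carboxylic acid at this position would also be tolerated remains open. Also open, from the compounds shown here alone, is whether any group here would give a number clearly lower than that of compound 1.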